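This account rests on a few compounds, and the source may have more. Where it says the series, first, only, none or still open, it means among the compounds named here.

Measured compounds in an ADME assay on the whole organism with Oryza sativa as the target, tested at 1 uM; on this read-out lower numbers stand for a stronger effect and higher numbers for a weaker effect at the one concentration tested:
compound 1 `Cc1ccc(NC(=O)N[C@@H](C)c2ccccc2)cc1` gives 99%
compound 2 `CCCc1ccc(NC(=O)N[C@@H](C)c2ccccc2)cc1` gives 76%
compound 3 `CCCCc1ccc(NC(=O)N[C@@H](C)c2ccccc2)cc1` gives 72%

Compound 1 stands highest of the three; the steps of a number 23 percentage points lower from compound 1 to compound 2 (beyond the scatter) and a number 27 percentage points lower from compound 1 to compound 3 (beyond the scatter) lie beyond the scatter, while a number 4 percentage points lower from compound 2 to compound 3 (within the scatter) does not. Compound 4 `Cc1ccc(NC(=O)N[C@@H](C)c2ccccc2)c(F)c1` has not yet been measured. It differs from compound 1 in one place: fluoro in place of hydrogen on an aromatic carbon. For the measured compounds named here, none of the measured steps touches an aromatic carbon; all three alter the methyl chain, so no measured step speaks to this change. A step of no more than the scatter is therefore expected. Compound 4 is expected to give about 94%, within 80% to 100%, meaning a step of a number 5 percentage points lower from compound 1 to compound 4 (within the scatter).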

Compound 4, a percentage reported as activity, at one concentration (the size of the read-out at that concentration, not a potency): 99%
Compound 4: the middle estimate sits 5 percentage points below what was measured, within the range that was stated.
By their numbers in this assay, from the lowest: compounds 3 and 2 (each within the scatter of the next); then compounds 1 and 4 (each within the scatter of the next).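

In this assay the swap of hydrogen for fluoro on the aromatic carbon ortho to a large group and meta to a methyl group gives no change at the digits printed from compound 1 to compound 4 (within the scatter) and so shows that this single fluorine leaves the read-out unchanged within the scatter. For the compounds shown here, this is the first look at the ring itself, since the earlier steps all altered the methyl chain. Nothing available here accounts for this result.

From the compounds shown here alone, whether a larger group at this position, such as chloro, methoxy or an amine, would also leave the number in place remains open. So does whether fluoro would do the same on the longer chains of compound 2 and compound 3.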